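Swapping the Benzyl Ether on a Shared Core

The compounds below may be only part of what the source reports. "The series", "measured", "known", "first", "only" and "open" are said of these compounds alone.

Compound 1 `COc1cc(OC)c(-c2coc3cc(OCc4ccccc4F)ccc3c2=O)cc1OC` and compound 2 `COc1cc(OC)c(-c2coc3cc(OCc4ccccc4C)ccc3c2=O)cc1OC` are built on the same core and differ only in the group carried by the benzyl ether. In a functional assay on HCT-116 cells (Homo sapiens) for antiproliferative activity, read by MTT assay, with a stated time of 24 h (a higher number here means a weaker inhibitor, a lower number a stronger inhibitor), compound 1 gives 2900 nM, and compound 2 gives 2900 nM. The one step measured so far, no change at the digits printed from compound 1 to compound 2 (within the scatter), leaves compound 1 level with compound 2, so on the numbers shown compound 1 stands with its single neighbour and nothing separates them.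

Compound 3 `COc1cc(OC)c(-c2coc3cc(OCc4ccc(C#N)cc4)ccc3c2=O)cc1OC` has not yet been tested in this assay. (4-cyanophenyl in place of 2-fluorophenyl on a saturated chain carbon bound to an oxygen on an aromatic ring). Among the compounds with values here, the only measured step bearing on this position of the molecule is the fluoro to methyl exchange, which produced no change within the scatter; no measured step addresses a 4-cyanophenyl or any nitrile-bearing group, so compound 1 is the sole anchor for what follows. The step from compound 1 to compound 3 is expected to be small, no change at the digits printed from compound 1 to compound 3 (within the scatter), with no direction that rises beyond the scatter. Compound 3 is therefore estimated to give about 2900 nM in this assay, in a range from 1200 nM to 7000 nM.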

Compound 3, half-maximal inhibitory concentration: 4220 nM
Beside the measured number, compound 3's estimate is 1.5-fold (0.16 log units) below it; the range from low to high includes it.
By their numbers in this assay, from the lowest: compounds 1, 2 and 3 (each within the scatter of the next).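

In this assay the exchange of 2-fluorophenyl for 4-cyanophenyl on the saturated chain carbon bound to an oxygen on an aromatic ring gives a 1.5-fold higher number from compound 1 to compound 3 (0.16 log units; within the scatter) and the exchange of 2-methylphenyl for the same group gives a 1.5-fold higher number from compound 2 to compound 3 (0.16 log units; within the scatter), so at this place the reading stays within the scatter even when the substituent on the phenyl ring and its place on that ring change together, which the earlier pair, both 2-substituted, could not show. The entering 4-cyanophenyl group also brings a triple bond and a hydrogen-bond acceptor that neither earlier group has, and neither addition separates compound 3 from compound 1 or compound 2 in this assay. Nothing available here measures any property that could account for this flat reading.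

The compounds shown leave open whether the reading would stay level with an amine or a carboxylic acid on the phenyl ring, or with a longer chain in place of the benzyl carbon. They also leave the nitrile and its place on the ring unseparated, since a 2-cyanophenyl or 4-fluorophenyl group does not stand among them.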